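From naphthalen-1-yl to phenyl in compound 4

The source may report more compounds than this note shows. Statements on the series, on what has been measured and on what is new or still open speak of the compounds shown alone.

Measured so far in an ADME assay on HEK-293T cells (Homo sapiens) for inhibition, read by CCK-8 assay, with a stated time of 48 h, tested at 20 uM (on this read-out higher numbers stand for more inhibition of growth at the one concentration tested and lower numbers for less inhibition of growth), are three compounds
compound 1 `COc1ccc(S(=O)(=O)Oc2ccccc2/C=C(\C#N)C(=O)Nc2nnc(Cc3cccc4ccccc34)s2)cc1` gives 29%
compound 2 `N#C/C(=C\c1ccccc1OS(=O)(=O)c1ccc([N+](=O)[O-])cc1)C(=O)Nc1nnc(Cc2cccc3ccccc23)s1` gives 25%
compound 3 `N#C/C(=C\c1ccccc1OS(=O)(=O)c1ccc(Cl)cc1)C(=O)Nc1nnc(Cc2cccc3ccccc23)s1` gives 16%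

Compound 2 has no firm rank among these: its two steps (a number 4 percentage points lower from compound 1 to compound 2 (within the scatter)) and (a number 9 percentage points lower from compound 2 to compound 3 (within the scatter)) both stay within the scatter. Only the remaining step (a number 13 percentage points lower from compound 1 to compound 3 (beyond the scatter)) clears it.

Compound 4 `N#C/C(=C\c1ccccc1OS(=O)(=O)c1ccc([N+](=O)[O-])cc1)C(=O)Nc1nnc(Cc2ccccc2)s1` keeps the nitro group of compound 2 but carries phenyl in place of naphthalen-1-yl on a saturated chain carbon bound to an aromatic carbon. Among the compounds with values here, no measured step touches this group, as all three exchange methoxy, nitro or chloro on an aromatic carbon. From the compounds shown here alone, they show only how far this small set has moved so far, so the new change remains untested and the range must stay wide. The expectation therefore starts from compound 2 at 25% and assumes no shift beyond the scatter in either direction. The expected step is small (a number 3 percentage points lower from compound 2 to compound 4 (within the scatter)) in this assay and carries little weight. For compound 4 the estimated value is 22% with an expected range from 8% to 38% (in this assay).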

Compound 4, percent growth inhibition at one concentration: "not toxic" (no number reported)
Nothing numeric was reported for compound 4; the estimate stays without a comparison.
By their numbers in this assay, from the lowest: compounds 3, 2 and 1 (each within the scatter of the next, the first and the last beyond it).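

Within the data shown here, compound 4 is reported in this assay only as "not toxic", with no number, so no step from compound 2 to compound 4 can be read. No further data bear on this result. The compounds shown leave open how far phenyl in place of naphthalen-1-yl shifts growth inhibition.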